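The source may hold more compounds than are shown below. What is called first, only, known or untested is meant among the compounds shown, and "the series" means these compounds.

Compound 1 `Cc1cc(/C=C/C#N)cc(C)c1Oc1nc(Nc2ccc(N3CCN(S(C)(=O)=O)CC3)cc2)nc2ccsc12` and compound 2 `Cc1cc(/C=C/C#N)cc(C)c1Oc1nc(Nc2ccc(N3CCN(S(C)(=O)=O)CC3)cc2)nc2sccc12` are built from the same atoms joined differently; how their two cores differ is not broken down here. In an ADME assay on MT4 cells (Homo sapiens) for cytotoxicity, read by MTT assay, with a stated time of 5 days (a higher number here means that more compound is tolerated, a lower number that less compound is tolerated), compound 1 gives 11500 nM. For compound 2 the result in this assay is a limit of the assay rather than a number, > 222000 nM, the point the limit of > 222000 nM in this assay, at which 1 of the 3 values shown sits, at which one of the three results so far sits.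

Compound 3 `Cc1cc(/C=C/C#N)cc(C)c1Oc1nc(Nc2ccc(CN3CCN(S(N)(=O)=O)CC3)cc2)nc2ccsc12` shares the core of compound 1 and differs from it in one place, ((4-sulfamoylpiperazin-1-yl)methyl in place of 4-(methylsulfonyl)piperazin-1-yl on an aromatic carbon). In this assay compound 3 gives 145000 nM. The step of a 13-fold higher number from compound 1 to compound 3 (1.10 log units; beyond the scatter) is large and beyond the scatter.

Compound 4 `Cc1cc(/C=C/C#N)cc(C)c1Oc1nc(Nc2ccc(CN3CCN(S(N)(=O)=O)CC3)cc2)nc2sccc12` has not been measured in this assay. It shares the core of compound 2 and differs from it in one place, ((4-sulfamoylpiperazin-1-yl)methyl in place of 4-(methylsulfonyl)piperazin-1-yl on an aromatic carbon). Going by the values given here, the description of the place in compound 2 matches word for word the description of the place in compound 1, so this is the same change as the one from compound 1 to compound 3.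

Because the same change in the core of compound 1 gave a 13-fold higher number from compound 1 to compound 3 (1.10 log units; beyond the scatter), a step of similar direction, a step that the limit leaves unreadable from compound 2 to compound 4, is expected from compound 2 to compound 4. Since the starting point is already the limit of the assay, compound 4 is expected to be tolerated at 350000 nM in this assay, with a range from 150000 nM to 900000 nM, and most likely the assay would again report only a limit.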

Compound 4, half-maximal cytotoxic concentration: > 217000 nM
Compound 4 ended at the assay's limit (the forecaster's own chance of this, stated with the estimate: 85%); the middle value is on the limit's open side.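

In this assay compound 4 gives only a limit of the assay, > 217000 nM. Going by these compounds alone, compound 2 likewise gives only a limit, > 222000 nM, so no step between compound 2 and compound 4 can be read. The compounds shown leave open how far (4-sulfamoylpiperazin-1-yl)methyl in place of 4-(methylsulfonyl)piperazin-1-yl shifts the number on the core of compound 2, and whether that shift matches the one seen on the core of compound 1.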